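Halogen exchange on the alkyne-linked aryl ring

The source may hold more compounds than are shown below. What is called first, only, known or untested is meant among the compounds shown, and "the series" means these compounds.

Measured compounds in a functional assay on HEK293 cells for antagonist activity at metabotropic glutamate receptor 5 (Rattus norvegicus), read by calcium flux; on this read-out higher numbers stand for weaker inhibition and lower numbers for stronger inhibition:
compound 1, `Cc1nc(C#Cc2cc(Br)cc([N+](=O)[O-])c2)cs1`: 0.73 nM
compound 2, `Cc1nc(C#Cc2cc(F)cc(Br)c2)cs1`: 1.11 nM

Going by the values given here, compound 2 holds the higher of the two numbers so far, though the only measured step, a 1.5-fold higher number from compound 1 to compound 2 (0.18 log units; within the scatter), stays within the scatter, so the two compounds cannot be ordered. Compound 3, `Cc1nc(C#Cc2cc(Br)cc(Br)c2)cs1`, differs from compound 2 by bromo in place of fluoro on an aromatic carbon. Among the compounds with values here, no measured step covers the exchange of one halogen for another; the single step known swaps nitro for fluoro and moves the number little. For compound 3 the expected change in this assay is therefore none beyond the scatter, a 1.1-fold lower number from compound 2 to compound 3 (0.05 log units; within the scatter), with an estimate of 1 nM and a range from 0.4 nM to 2.8 nM.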

Compound 3, half-maximal inhibitory concentration: 1.45 nM
Compound 3: middle estimate off by 1.5-fold (0.16 log units), on the low side; the range from low to high includes it.
By their numbers in this assay, from the lowest: compounds 1, 2 and 3 (each within the scatter of the next).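

In this assay the aromatic carbon that holds fluoro in compound 2 also accepts bromo with no change beyond the scatter (a 1.3-fold higher number from compound 2 to compound 3 (0.12 log units; within the scatter)). Bromo in place of nitro likewise stays within the scatter (a 2.0-fold higher number from compound 1 to compound 3 (0.30 log units; within the scatter)), so nitro, fluoro and bromo at this carbon cannot be told apart on these numbers. No evidence is available that would explain this result.

Open, on these data alone, is whether an amine, a carboxylic acid or a methoxy group at this carbon would move the number beyond the scatter. Also open, as far as these compounds go, is whether the bromo shared by all three compounds can be replaced with the same outcome.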